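The compounds below may be only part of what the source reports. "The series", "measured", "known", "first", "only" and "open" are said of these compounds alone.

Measured in an ADME assay on MT2 cells (Homo sapiens) for cytotoxicity; a higher number here means that more compound is tolerated, a lower number that less compound is tolerated:
- compound 1 `Cc1cc(C#N)cc(C)c1Oc1cc(Nc2ccc(C#N)cc2)c(N)cc1CO`: 122000 nM
- compound 2 `CNCc1cc(N)c(Nc2ccc(C#N)cc2)cc1Oc1c(C)cc(C#N)cc1C`: 12700 nM
- compound 3 `CC(=O)OCc1cc(N)c(Nc2ccc(C#N)cc2)cc1Oc1c(C)cc(C#N)cc1C`: 113000 nM

In this assay, compound 3 gives 113000 nM, and it cannot be told apart from compound 1, as a 1.1-fold lower number from compound 1 to compound 3 (0.03 log units; within the scatter) shows. Compound 2 is the only clear outlier of the three, as an 8.9-fold higher number from compound 2 to compound 3 (0.95 log units; beyond the scatter) shows.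

Compound 4 `CC(=O)OCc1cc(N)c(Nc2ccc(C#N)cc2)cc1Oc1c(C)cc(/C=C/C#N)cc1C` keeps the acetoxy group of compound 3 and changes the other end of the molecule: 2-cyanoethenyl in place of cyano on an aromatic carbon. In short, 2-cyanoethenyl stands in place of cyano on an aromatic carbon.

Among the compounds with values here, no measured step touches that aromatic carbon. All three steps concern the saturated chain carbon, so they offer only a rough gauge of size. Acetylating the hydroxy group of compound 1 gave a 1.1-fold lower number from compound 1 to compound 3 (0.03 log units; within the scatter), while the methylamino exchange gave a 9.6-fold lower number from compound 1 to compound 2 (0.98 log units; beyond the scatter). A change at a new place could fall anywhere in that span. With compound 3 among the higher numbers seen so far, a modest move to a lower number seems more likely than a rise, though the data do not settle this.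

The expected change is a 2.3-fold lower number from compound 3 to compound 4 (0.35 log units; beyond the scatter). For compound 4 the estimate is 50000 nM, with an expected range from 12000 nM to 150000 nM.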

Compound 4, half-maximal cytotoxic concentration: 96300 nM
Compound 4: middle estimate off by 1.9-fold (0.28 log units), on the low side; the range from low to high includes it.
By their numbers in this assay, from the lowest: compound 2; then compounds 4, 3 and 1 (each within the scatter of the next).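

Within the data shown here, the first step at this aromatic carbon, a 1.2-fold lower number from compound 3 to compound 4 (0.07 log units; within the scatter), stays within the scatter of this assay, so the exchange of cyano for 2-cyanoethenyl cannot be told from no change. The position therefore accepts a group of 4 heavy atoms in place of one of 2, with the double bond added outside the aromatic rings, and the reading in this assay stays level with that of compound 3. Among these compounds, this differs from the methylamino exchange on the saturated chain carbon, a 9.6-fold lower number from compound 1 to compound 2 (0.98 log units; beyond the scatter), which remains the only step away from the other compounds that lies beyond the scatter, and nothing available explains why the aromatic carbon tolerates its change.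

Both groups seen at this aromatic carbon end in a nitrile, so the compounds shown leave open whether an amine or a carboxylic acid there would also leave the number in place. They also leave open whether 2-cyanoethenyl would behave the same way with hydroxy or methylamino on the saturated chain carbon instead of acetoxy.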